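Carbamate ester swap in the dithiocarbamate piperazine series

A few compounds are considered here, and "the series" means these few. Any claim that something is new, unique, unknown or untested is made for them only; others in the source may bear on it.

Measured so far:
compound 1 `COc1ccc(Cn2cc(CSC(=S)N3CCN(C(=O)OCc4ccccc4)CC3)nn2)cc1`: 58300 nM
compound 2 `CC(C)(C)OC(=O)N1CCN(C(=S)SCc2cn(Cc3ccc(Cl)c(Cl)c3)nn2)CC1`: > 128000 nM

In a functional assay on ECa-109 cells (Homo sapiens) for inhibition, read by MTT assay, with a stated time of 72 h (on this read-out higher numbers stand for weaker inhibition and lower numbers for stronger inhibition), compound 1 gives 58300 nM. Compound 2 returns only a limit, > 128000 nM, and so stands at the limit of > 128000 nM in this assay, at which 1 of the 2 values shown sits. Compound 3 `O=C(OCc1ccccc1)N1CCN(C(=S)SCc2cn(Cc3ccc(Cl)c(Cl)c3)nn2)CC1` remains to be measured; it differs from compound 2 by benzyl in place of tert-butyl on an oxygen next to a carbonyl group. Among the compounds with values here, with no measured step of this kind to lean on, the expected step of an at least 1.3-fold lower number from compound 2 to compound 3 (0.12 log units; that floor lies within the scatter) is taken as small, if anything toward stronger inhibition, and not clearly beyond the scatter. Compound 3 is therefore estimated at 95000 nM, within 40000 nM to 200000 nM, with a real chance that this assay again reports only a limit.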

Compound 3, half-maximal inhibitory concentration: 29400 nM
Beside the measured number, compound 3's estimate is 3.2-fold (0.51 log units) above it; measured number below the stated range.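

Working from this assay, benzyl in place of tert-butyl on an oxygen next to a carbonyl group gives an at least 4.3-fold lower number from compound 2 to compound 3 (0.63 log units; beyond the scatter), so this position affects the read-out in this series. Compound 2 holds only a limit, so that step is a floor and its full size stays unknown: the limit of > 128000 nM in this assay, at which 1 of the 3 values shown sits.

3,4-dichlorophenyl in place of 4-methoxyphenyl gives a 2.0-fold lower number from compound 1 to compound 3 (0.30 log units; within the scatter), which does not separate the two groups.

Open, on these data alone, is whether the aromatic ring of benzyl is what matters on this oxygen. Cyclohexylmethyl or 4-chlorobenzyl there would test that.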